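A few compounds are considered here, and "the series" means these few. Any claim that something is new, unique, unknown or untested is made for them only; others in the source may bear on it.

In a functional assay on MCF7 cells (Homo sapiens) for inhibition, read by sulforhodamine B assay, with a stated time of 48 h (on this read-out lower numbers stand for stronger inhibition of growth and higher numbers for weaker inhibition of growth), compound 1 (`CCOC(=O)c1nn(-c2ccccc2)c(-c2ccc(F)cc2)c1CNC(C)(C)C`) gives 306000 nM; 517000 nM (2 entries), and compound 2 (`CCOC(=O)c1nn(-c2ccccc2)c(-c2ccc([N+](=O)[O-])cc2)c1CNC(C)(C)C`) gives 206000 nM; 169000 nM (2 entries). Compound 3 (`CC(C)(C)NCc1c(C(=O)O)nn(-c2ccccc2)c1-c1ccc(F)cc1`) has no single number to its name. Its entry of > 680000 nM is a limit of the assay, and its two further entries carry no single number either. Its place in this assay is therefore known only as a limit.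

Compound 4 (`Cc1ccc(-c2c(CNC(C)(C)C)c(C(=O)O)nn2-c2ccccc2)cc1`) differs from compound 3 in one place, the change from 4-fluorophenyl to 4-methylphenyl: methyl in place of fluoro on an aromatic carbon. This is methyl in place of fluoro on an aromatic carbon, para to a large group. Among the compounds with values here, no measured pair shows what this exchange does in this assay, so no direction can be favoured. The expected change, a step that the limit leaves unreadable from compound 3 to compound 4, is none beyond the scatter. This expectation rests on compound 3 and its limit of > 680000 nM. A further limit rather than a number would be no surprise. For compound 4 the estimated value is 700000 nM, with an expected range from 300000 nM to 1500000 nM.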

Compound 4, concentration for 50% growth inhibition: > 688000 nM
Compound 4 ended at the assay's limit; the forecaster's own chance of this, stated with the estimate: 65%; the middle value lies beyond the limit too.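

In this assay compound 3 gives only a limit, > 680000 nM. Compound 4 likewise gives only a limit, > 688000 nM, so no step can be read between compound 3 and compound 4. The compounds shown leave open what methyl in place of fluoro on an aromatic carbon does to growth inhibition.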